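Notes on a side-chain amine swap, compound 1 to compound 4

A few compounds are considered here, and "the series" means these few. Any claim that something is new, unique, unknown or untested is made for them only; others in the source may bear on it.

Going by the values given here, compound 1 `COc1c(OCCCCNCc2ccccc2)cc(O)c2c(=O)cc(-c3ccccc3)oc12` is the one member of the set with a number in hand. In a functional assay on A549 cells (Homo sapiens) for cytotoxicity, read by MTT assay, with a stated time of 48 h (a lower number here means a stronger inhibitor, a higher number a weaker inhibitor), compound 1 gives 4590 nM. Two further members carry no result: compound 2 `CCCNCCOc1c(O)cc(O)c2c(=O)cc(-c3ccccc3)oc12` gives "not determined" (no result reported) and compound 3 `O=c1cc(-c2ccccc2)oc2c(OCCNCCO)c(O)cc(O)c12` gives "not determined" (no result reported). Compound 1 therefore stands alone on the numbers shown, with nothing in the set to rank it against, neither a stronger nor a weaker neighbour.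

Compound 4 `COc1c(OCCCCN2CCNCC2)cc(O)c2c(=O)cc(-c3ccccc3)oc12` is not yet measured. Against compound 1 it differs in one place: piperazin-1-yl in place of benzylamino on a saturated chain carbon, four bonds along the chain from an oxygen on an aromatic ring. Among the compounds with values here, no pair of measured compounds in the set differs in a single place, so no step within the set shows what such a swap does in this assay. Within the data shown here, the set gives no guide to the direction of the change, and the only number to lean on is compound 1 at 4590 nM. The step of a 1.1-fold higher number from compound 1 to compound 4 (0.04 log units; within the scatter) is expected to stay within the usual scatter, with no preferred direction. Compound 4 is estimated at 5000 nM in this assay, with a range from 1500 nM to 16000 nM to cover the uncertainty of a single-point comparison.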

Compound 4, half-maximal inhibitory concentration: 1740 nM
Estimate against measurement, compound 4: 2.9-fold (0.46 log units) above; measured number inside the range.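

In this assay, piperazin-1-yl in place of benzylamino on a saturated chain carbon, four bonds along the chain from an oxygen on an aromatic ring, gives a 2.6-fold lower number from compound 1 to compound 4 (0.42 log units; beyond the scatter), the first single-place step available in this series. The number at this position therefore does respond to the group carried at the end of the chain, and the carbon-only aromatic ring of benzylamino is not needed to hold it: the non-aromatic ring with 2 hetero atoms gives the lower number on the same core. Going by these compounds alone, no measurement in hand accounts for the change, and the single step fixes a direction for this one swap only.

As far as these compounds go, the two entries with no reported result cannot be read, so this single pair is all there is to say about the side chain, and how far the trend extends remains open. Whether piperidin-1-yl or morpholin-4-yl at the same place would follow piperazin-1-yl, and whether a longer chain would keep the step, would separate the contribution of the ring from that of its second nitrogen.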